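The source may hold more compounds than are shown below. What is called first, only, known or untested is meant among the compounds shown, and "the series" means these compounds.

In a functional assay, read by spectrophotometry, with a stated time of 20 min (on this read-out lower numbers stand for stronger inhibition and higher numbers for weaker inhibition), compound 1 `Cc1c(-c2ccccc2)oc2ccccc2c1=O` gives 106 ug/mL and compound 2 `Cc1ccccc1-c1oc2ccccc2c(=O)c1C` gives 156 ug/mL, so compound 2 stands within the scatter of compound 1. Compound 3 `Cc1c(-c2ccccc2Br)oc2ccccc2c1=O` carries bromo in place of methyl on an aromatic carbon, that is, bromo in place of methyl on an aromatic carbon. For the measured compounds named here, the only measured step bearing on this change is a 1.5-fold higher number from compound 1 to compound 2 (0.17 log units; within the scatter), which involves methyl and hydrogen, not bromo. No step beyond the scatter is therefore expected in this assay. The estimated change is a 1.2-fold lower number from compound 2 to compound 3 (0.08 log units; within the scatter). For compound 3 the expected value is 130 ug/mL, with an estimated range of 70 ug/mL to 240 ug/mL.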

Compound 3, half-maximal inhibitory concentration: 70.4 ug/mL
For compound 3 the middle estimate is 1.8-fold (0.27 log units) above the measured one; low and high end bracket the measured number.
By their numbers in this assay, from the lowest: compounds 3, 1 and 2 (each within the scatter of the next, the first and the last beyond it).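

In this assay, for the compounds shown here, the change at this place on the aromatic ring, ortho to a large group, gives the first step beyond the scatter, with a 2.2-fold lower number from compound 2 to compound 3 (0.35 log units; beyond the scatter) for bromo in place of methyl. With hydrogen as the reference, a 1.5-fold lower number from compound 1 to compound 3 (0.18 log units; within the scatter) stays within the scatter, so bromo is separated from methyl here but not from hydrogen. Nothing available explains this difference between bromo and methyl. Open, going by these compounds, is whether chloro, methoxy, an amine or a carboxylic acid at this place would follow bromo or methyl. Also open, on these data alone, is whether bromo gives a similar step elsewhere on this ring.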